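The compounds below may be only part of what the source reports. "The series", "measured", "known", "first", "only" and "open" are said of these compounds alone.

Compound 1 `O=C(O)CN1C(=O)/C(=C/C2=Cc3ccccc3OC2)SC1=S` with > 100000 nM; compound 2 `O=C(O)CN1C(=O)/C(=C/C2=Cc3cc(Br)ccc3OC2)SC1=S` with > 25000 nM.

In a functional assay on MCF7 cells (Homo sapiens) for antiproliferative activity, read by MTT assay, with a stated time of 72 h (a lower number here means a stronger inhibitor, a higher number a weaker inhibitor), compound 1 gives > 100000 nM, which is a limit of the assay and not a number. Compound 2 gives > 25000 nM, likewise only a limit. The step that the two limits leave unreadable from compound 1 to compound 2 therefore cannot be read, as the limit of > 100000 nM in this assay, at which 1 of the 2 values shown sits, and the limit of > 25000 nM in this assay, at which 1 of the 2 values shown sits, show. Compound 3 `CC1Oc2ccc(Br)cc2C=C1/C=C1\SC(=S)N(CC(=O)O)C1=O` differs from compound 2 by methyl in place of hydrogen on a saturated ring carbon. Within the data shown here, no measured step bears on this change, and compound 2 stands only at a limit. The expected step is a step that the limit leaves unreadable from compound 2 to compound 3 in this assay, most probably ending again at a limit. The estimate for compound 3 is 60000 nM, between 20000 nM and 200000 nM.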

Compound 3, half-maximal inhibitory concentration: > 50000 nM
Compound 3 gave a limit, no number (the forecaster's own chance of this, stated with the estimate: 80%); the middle value does not contradict the limit.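

Compound 2 and compound 3 each give only a limit, not a number, in this assay, and the step between them cannot be read. The compounds shown leave open what methyl in place of hydrogen on a saturated ring carbon does to activity.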